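Phenyl for thiophen-2-yl on a nucleoside core

The source may report more compounds than this note shows. Statements on the series, on what has been measured and on what is new or still open speak of the compounds shown alone.

Compound 1 `C#Cc1cn([C@@H]2O[C@H](CO)[C@@H](O)[C@H]2O)c2ncnc(OC)c12` gives 8160 nM in a functional assay on A549 cells (Homo sapiens), read by MTT assay, with a stated time of 72 h; a higher number here means a weaker inhibitor, a lower number a stronger inhibitor. Compound 2 `Cc1ncnc2c1c(-c1cccs1)cn2[C@@H]1O[C@H](CO)[C@@H](O)[C@H]1O` reaches only the limit of this assay, > 20000 nM. Compound 3 `COc1ncnc2c1c(-c1cccs1)cn2[C@@H]1O[C@H](CO)[C@@H](O)[C@H]1O` gives 4850 nM.

Compound 3 stands alongside compound 1 in this assay: a 1.7-fold lower number from compound 1 to compound 3 (0.23 log units; within the scatter). The other step leading to compound 3 is larger: an at least 4.1-fold lower number from compound 2 to compound 3 (0.61 log units; beyond the scatter), though one end of it is a limit (the limit of > 20000 nM in this assay, at which 1 of the 3 values shown sits).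

Compound 4 `COc1ncnc2c1c(-c1ccccc1)cn2[C@@H]1O[C@H](CO)[C@@H](O)[C@H]1O` differs from compound 3 in a single place: phenyl in place of thiophen-2-yl on an aromatic carbon. Among the measured compounds shown here, only one measured step touches the same place, and that is the step from compound 1 to compound 3, which swapped ethynyl for thiophen-2-yl on that aromatic carbon and stayed within the scatter. The methoxy group, which set compound 3 apart from compound 2, is kept in compound 4. On this basis the change to phenyl is expected to move the number little, in neither direction beyond the scatter, so a 1.1-fold higher number from compound 3 to compound 4 (0.05 log units; within the scatter) is the estimated step. Compound 4 is therefore expected to give about 5500 nM in this assay, with a range from 2000 nM to 16000 nM.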

Compound 4, half-maximal inhibitory concentration: > 20000 nM
Compound 4: no number, only a limit (the forecaster's own chance of this, stated with the estimate: 10%); at least 3.6-fold (0.56 log units) between middle value and limit.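

The aromatic carbon two ring bonds from the ring nitrogen proves more selective in this assay than the step from ethynyl to thiophen-2-yl suggested, since phenyl, with the methoxy group kept, costs activity (an at least 4.1-fold higher number from compound 3 to compound 4 (0.61 log units; beyond the scatter)). Phenyl also falls behind the small ethynyl group on the same carbon (an at least 2.4-fold higher number from compound 1 to compound 4 (0.38 log units; beyond the scatter)), so thiophen-2-yl and ethynyl stay within the scatter of each other while phenyl does not. Compound 4 gives only a limit, not a number, and the methoxy group alone therefore does not keep activity, as this limit shows: (the limit of > 20000 nM in this assay, at which 2 of the 4 values shown sit).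

On these data alone, how far compound 4 lies past its limit stays open, and with it the true size of both steps. So does whether furan-2-yl, an amine or a longer chain on this carbon would stay level with thiophen-2-yl.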